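Trading the Ester Side Chain for a Short Hydroxyethyl Ether

The source may report more compounds than this note shows. Statements on the series, on what has been measured and on what is new or still open speak of the compounds shown alone.

Measured compounds:
Compound 1 `CCCC(O)CC(=O)O[C@H](CC=C(C)C)C1=CC(=O)c2c(O)ccc(O)c2C1=O` gives 59300 nM in a functional assay on HeLa cells (Homo sapiens) for cytotoxicity, read by MTT assay; a lower number here means a stronger inhibitor, a higher number a weaker inhibitor.
Compound 2 `CC[C@](C)(O)CC(=O)O[C@H](CC=C(C)C)C1=CC(=O)c2c(O)ccc(O)c2C1=O` gives 30200 nM.
Compound 3 `CC(C)=CC[C@@H](OC(=O)CC(C)(O)C(C)C)C1=CC(=O)c2c(O)ccc(O)c2C1=O` gives 27700 nM.

Compound 1 has the highest number of the three, so it is the weakest inhibitor of this set; compound 2 lies nearest to it and compound 3 furthest. The measured steps all keep the ester and alter only the branch on the saturated chain carbon bound to the carbonyl carbon: a 2.0-fold lower number from compound 1 to compound 2 (0.29 log units; within the scatter), a 2.1-fold lower number from compound 1 to compound 3 (0.33 log units; beyond the scatter) and a 1.1-fold lower number from compound 2 to compound 3 (0.04 log units; within the scatter). None of these changes moves the number by more than a modest amount.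

Compound 4 `CC(C)=CC[C@@H](OCCO)C1=CC(=O)c2c(O)ccc(O)c2C1=O` departs further. 2-hydroxyethyl in place of (2-hydroxypentyl)carbonyl on an oxygen on a saturated carbon The whole ester group leaves and a small 2-hydroxyethyl group enters on the oxygen on the saturated carbon; the shared core of compound 1 is untouched. Going by the values given here, no measured pair covers a change of this kind, so the expectation rests on the observation that varying the side chain so far has produced only small shifts. The estimate for compound 4 is therefore 50000 nM, with a wide range from 15000 nM to 160000 nM. This estimate means a 1.2-fold lower number from compound 1 to compound 4 (0.07 log units; within the scatter), which is expected to remain within the scatter.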

Compound 4, half-maximal inhibitory concentration: 18600 nM
Compound 4: middle estimate off by 2.7-fold (0.43 log units), on the high side, and the stated range covers the measured number.
By their numbers in this assay, from the lowest: compounds 4, 3, 2 and 1 (each within the scatter of the next, the first and the last beyond it).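

Compound 1 can lose its whole (2-hydroxypentyl)carbonyl group from this oxygen, with the much smaller 2-hydroxyethyl group taking its place, and this assay still gives a measurable value, with a 3.2-fold lower number from compound 1 to compound 4 (0.50 log units; beyond the scatter). Set against the two branched esters, the same kind of swap gives a 1.5-fold lower number from compound 3 to compound 4 (0.17 log units; within the scatter) and a 1.6-fold lower number from compound 2 to compound 4 (0.21 log units; within the scatter), so compound 4 cannot be told apart from compound 2 or compound 3. The earlier compounds only varied the branching inside the ester, whereas this result shows that, in this small set, neither the ester carbonyl nor the longer side chain is needed to reach numbers of this size, and nothing shown here accounts for that.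

Still open, going by these compounds, is whether the hydroxyl at the end of the new group matters, which a plain ethyl group or a 2-aminoethyl group on the same oxygen would test. Also open, on these data alone, is how far this ether can be changed, for instance by a longer chain such as 3-hydroxypropyl or by a carboxylic acid at its end.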